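From thiophen-2-yl to 1,3-thiazol-2-yl in liver microsomes

The source may report more compounds than this note shows. Statements on the series, on what has been measured and on what is new or still open speak of the compounds shown alone.

Compound 1 `CC(=O)N[C@@H]1CCN(c2cc(C)nn3c(-c4ccc(C#N)cc4)c(C)nc23)C1`: > 95%
Compound 2 `CC(=O)N[C@@H]1CCN(c2cc(C)nn3c(-c4cccs4)c(C)nc23)C1`: > 95%

Both compounds were tested in an ADME assay on microsomes from liver (Homo sapiens) for metabolic stability, read by LC-MS, with NADPH named in the record, with a stated time of 60 min, tested at 1 uM, in the absence of a further agent; a lower number here means that less of the compound is left, a higher number that more of the compound is left. Compound 1 gives > 95%, which is a limit of the assay and not an exact number. Compound 2 gives > 95%, which is also a limit. The two compounds therefore share (the limit of > 95% in this assay, at which 2 of the 2 values shown sit), and compound 2 cannot be placed more exactly.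

Compound 3 `CC(=O)N[C@@H]1CCN(c2cc(C)nn3c(-c4nccs4)c(C)nc23)C1` keeps the shared core but carries 1,3-thiazol-2-yl in place of thiophen-2-yl on an aromatic carbon. One five-membered aromatic ring is thus exchanged for another.

Among the compounds with values here, only one measured step bears on this change: a step that the two limits leave unreadable from compound 1 to compound 2. In that step, thiophen-2-yl replaces 4-cyanophenyl at the same place, and its size cannot be read. Still, both compounds stay at the limit. Compound 2, at > 95%, is the closest measured relative of compound 3, so no change beyond the usual scatter is expected in this assay. The expected size is a number no higher from compound 2 to compound 3 (the limit leaves the size open). For compound 3 the estimated value is 95%, with an expected range from 84% to 100%.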

Compound 3, percent of the compound remaining: > 95%
Compound 3: a limit, no number (the forecaster's own chance of this, stated with the estimate: 55%); the middle value sits exactly at the limit.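

In this assay compound 3 gives > 95% which is a limit of the assay and not a number. Within the data shown here, no step among compound 1, compound 2 and compound 3 can therefore be read: the limit of > 95% in this assay, at which 3 of the 3 values shown sit. These compounds leave open whether 4-cyanophenyl, thiophen-2-yl and 1,3-thiazol-2-yl differ at all in how much compound remains.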